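Extending the Chain on the Shared Core Past Ethyl

This account rests on a few compounds, and the source may have more. Where it says the series, first, only, none or still open, it means among the compounds named here.

Of the compounds shown here, three built on one shared core have been measured in an assay on Jurkat cells for activation of nuclear factor NF-kappa-B complex (Homo sapiens); on this read-out lower numbers stand for stronger inhibition and higher numbers for weaker inhibition. Compound 1 `Cc1nc(Cl)ncc1C(=O)Nc1cc(C(F)(F)F)cc(C(F)(F)F)c1` carries a methyl group on the core and gives 50 nM. Compound 2 `CCc1nc(Cl)ncc1C(=O)Nc1cc(C(F)(F)F)cc(C(F)(F)F)c1` carries an ethyl group in the same place and gives 400 nM. Compound 3 `O=C(Nc1cc(C(F)(F)F)cc(C(F)(F)F)c1)c1cnc(Cl)nc1` has hydrogen there and gives 300 nM, the second highest of the three numbers: it lies within the scatter of compound 2, with a 1.3-fold lower number from compound 2 to compound 3 (0.12 log units; within the scatter), and beyond the scatter of compound 1, with a 6.0-fold higher number from compound 1 to compound 3 (0.78 log units; beyond the scatter).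

Compound 4 `CCCc1nc(Cl)ncc1C(=O)Nc1cc(C(F)(F)F)cc(C(F)(F)F)c1` differs from compound 3 by a single change, (propyl in place of hydrogen on an aromatic carbon). Among the measured compounds shown here, two measured steps bear on this change. The first, a 6.0-fold higher number from compound 1 to compound 3 (0.78 log units; beyond the scatter), shows that a methyl group in this place is linked to a clearly lower number. The second, a 1.3-fold lower number from compound 2 to compound 3 (0.12 log units; within the scatter), shows that an ethyl group gives no difference beyond the scatter. The step of an 8.0-fold higher number from compound 1 to compound 2 (0.90 log units; beyond the scatter) shows that lengthening the chain from methyl to ethyl moved the number up. A propyl chain extends this further, so no large gain is expected; a step of a 1.7-fold higher number from compound 3 to compound 4 (0.22 log units; within the scatter) is expected, small and within the scatter. Compound 4 is estimated at 500 nM, with a range from 150 nM to 2000 nM.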

Compound 4, half-maximal inhibitory concentration: 500 nM
Compound 4: middle estimate and measured number agree at the digits printed; the measured number falls inside the stated range.
By their numbers in this assay, from the lowest: compound 1; then compounds 3, 2 and 4 (each within the scatter of the next).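

In this assay, propyl in place of hydrogen on this aromatic carbon, next to the ring nitrogen, gives no difference beyond the scatter, with a 1.7-fold higher number from compound 3 to compound 4 (0.22 log units; within the scatter). Adding one more carbon to the ethyl chain likewise gives a 1.3-fold higher number from compound 2 to compound 4 (0.10 log units; within the scatter), so hydrogen, ethyl and propyl now cannot be told apart at this position, and the number does not keep climbing as the chain grows past ethyl. Methyl alone stands apart, with a 10-fold higher number from compound 1 to compound 4 (1.00 log units; beyond the scatter), which leaves compound 1 as the strongest inhibitor of the four and makes the lower number specific to methyl among the groups shown, rather than a trend along the chain.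

Nothing shown explains why methyl differs from hydrogen, ethyl and propyl here. From the compounds shown here alone, it also remains open whether a butyl chain, a branched isopropyl group, a cyclopropyl ring, a methoxy group or an amine in this place would give a number like that of compound 1 or join the other three compounds.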